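Shortening the Amine Chain of Compound 2

The source may report more compounds than this note shows. Statements on the series, on what has been measured and on what is new or still open speak of the compounds shown alone.

Values so far in a functional assay on NCI-H460 cells (Homo sapiens) for cytotoxicity, read by MTT assay, with a stated time of 72 h (a lower number here means a stronger inhibitor, a higher number a weaker inhibitor), are these
Compound 1 `CCCCNC1=CC(=O)C(C[C@]2(C)[C@@H](C)CC[C@]3(C)C(C)=CCC[C@@H]23)=CC1=O` gives > 100000 nM (a limit, not a number)
Compound 2 `CCCCCCCCNC1=CC(=O)C=C(C(C)(C)C)C1=O` gives 21000 nM (the only true number)

Among the compounds with values here, compound 2 is the only compound with a true number here, so it cannot yet be ranked against another measured value. Compound 3 `CNC1=CC(=O)C=C(C(C)(C)C)C1=O` shares the core of compound 2 and differs on the amine chain, with hydrogen in place of heptyl on a saturated chain carbon bound to an amine nitrogen. Within the data shown here, no measured pair shows what this change does, so the expectation is loose and starts from compound 2 at 21000 nM as its only anchor. A modest weakening is expected in this assay, meaning a higher number, with an expected step of a 1.9-fold higher number from compound 2 to compound 3 (0.28 log units; within the scatter) in that direction. The estimate for compound 3 is 40000 nM as a middle value, with an expected range from 12000 nM to 100000 nM across repeated measurements.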

Compound 3, half-maximal inhibitory concentration: 23000 nM
Estimate against measurement, compound 3: 1.7-fold (0.24 log units) above, and the stated range covers the measured number.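

In this assay, the change of hydrogen in place of heptyl on a saturated chain carbon bound to an amine nitrogen gives a 1.1-fold higher number from compound 2 to compound 3 (0.04 log units; within the scatter). Within the data shown here, this is the first measured pair on this core, and it shows that, for these two compounds, removing the heptyl part of the chain leaves a difference that cannot be told apart from the scatter of repeated measurements. Only compound 1 stands at a limit, which is not a number: the limit of > 100000 nM in this assay, at which 1 of the 3 values shown sits.

The pair covers only the methyl-bearing amine of compound 3 and the long chain of compound 2, so it cannot show whether every chain at this place behaves alike. Going by these compounds, whether a chain ending in a carboxylic acid or an amine, or a phenyl ring in place of the chain, would give a similar number remains open.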